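The source may hold more compounds than are shown below. What is called first, only, known or untested is meant among the compounds shown, and "the series" means these compounds.

Measured in an ADME assay on BJ cells (Homo sapiens) for cytotoxicity, with a stated time of 72 h; a lower number here means that less compound is needed, a higher number that more compound is needed for the effect:
Compound 1 `C=C[C@@](C)(/C=C/c1ccc(Nc2ccc(OC)c(F)c2)cc1)CCC=C(C)C`: > 36600 nM (a limit)
Compound 2 `C=C[C@@](C)(/C=C/c1ccc(Nc2ccc(OC(F)(F)F)cc2)cc1)CCC=C(C)C`: > 36600 nM (a limit)

Among the measured compounds shown here, neither result is a number, and no step between the two compounds can be read from them. Compound 2 stands at the limit of > 36600 nM in this assay, at which 2 of the 2 values shown sit. Its position therefore gives no exact reference point, only the limit of this assay.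

Compound 3 `C=C[C@@](C)(/C=C/c1ccc(Nc2ccc(F)cc2)cc1)CCC=C(C)C` has not yet been measured. It carries fluoro in place of trifluoromethoxy on an aromatic carbon, para to a large group: fluoro in place of trifluoromethoxy on an aromatic carbon. The rest of the structure is unchanged.

For the measured compounds named here, with no measured step as a guide, the expectation is for no change beyond the scatter in this assay, and direction cannot be assigned. This expectation rests on compound 2, whose value of > 36600 nM is a limit. The expected step is a step that the limit leaves unreadable from compound 2 to compound 3, none beyond the scatter. Compound 3 will most likely be reported as a limit again. The estimated value for compound 3 is 38000 nM, with an expected range from 20000 nM to 70000 nM.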

Compound 3, half-maximal effective concentration: > 36600 nM
Compound 3: only a limit was reported; the forecaster's own chance of this, stated with the estimate: 80%; the middle value does not contradict the limit.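

In this assay compound 3 gives > 36600 nM, which is a limit and not a number. No step from compound 1 or compound 2 to compound 3 can be read, because all three results are limits: the limit of > 36600 nM in this assay, at which 3 of the 3 values shown sit.

The compounds shown leave open whether fluoro in place of trifluoromethoxy changes the concentration needed in this assay at all.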